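A few compounds are considered here, and "the series" means these few. Any claim that something is new, unique, unknown or untested is made for them only; others in the source may bear on it.

The measured compounds:

compound 1, `O=c1nc2oc(CCCCCCCCCOCC3CCCC3)cc2cn1[C@H]1C[C@H](O)[C@@H](CO)O1`: >= 5000 nM
compound 2, `CCCCOCCCCCCCCCc1cc2cn([C@H]3C[C@H](O)[C@@H](CO)O3)c(=O)nc2o1`: 20000 nM

In a functional assay on HEL cells (Homo sapiens) for cytotoxicity (on this read-out lower numbers stand for higher toxicity in this test and higher numbers for lower toxicity in this test), compound 1 gives >= 5000 nM, which is a limit of the assay and not a number. In this assay compound 2 gives 20000 nM. The step that the limit leaves unreadable from compound 1 to compound 2 cannot be sized because of the limit of >= 5000 nM in this assay, at which 1 of the 2 values shown sits; the position of compound 1 on the shown numbers is therefore known only as a limit.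

Compound 3, `O=c1nc2oc(CCCCCCCCCOCCCCCl)cc2cn1[C@H]1C[C@H](O)[C@@H](CO)O1`, differs from compound 1 by 3-chloropropyl in place of cyclopentyl on a saturated chain carbon bound to an oxygen on a saturated carbon. Within the data shown here, the only measured step that touches the same place is the one from compound 1 to compound 2, and its size is unreadable, so there is no measured basis for expecting a step beyond the scatter in this assay in either direction. The step that the limit leaves unreadable from compound 1 to compound 3 is therefore expected to stay within the usual scatter. Compound 3 is expected to give about 10000 nM, with a range from 3000 nM to 40000 nM.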

Compound 3, minimum cytotoxic concentration: >= 200000 nM
Compound 3 gave a limit, no number; the forecaster's own chance of this, stated with the estimate: 50%; middle value at least 20-fold (1.30 log units) away from the limit.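

In this assay, among these compounds, chloro in place of hydrogen on a saturated chain carbon, four bonds along the chain from an oxygen on a saturated carbon, gives an at least 10-fold higher number from compound 2 to compound 3 (1.00 log units; beyond the scatter), the first readable step at this end of the chain and one beyond the scatter. Compound 3 gives >= 200000 nM, which is a limit of the assay and not a number. The step between compound 1 and compound 3 cannot be read, so the shown values do not place the 3-chloropropyl group against the cyclopentyl group.

On these data alone, how far the true value of compound 3 lies from its limit remains open. Also open, as far as these compounds go, is whether the step belongs to chloro alone or would also appear with bromo, a hydroxyl or an amine at the same chain end.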